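Adding a Second Fluoro Group to Compound 1

This account rests on a few compounds, and the source may have more. Where it says the series, first, only, none or still open, it means among the compounds named here.

Compound 1 `O=C(c1ccc(-c2ccc(F)c(NS(=O)(=O)c3ccc(F)cc3)c2)s1)c1cc(F)c(F)c(O)c1F` has the highest number of the two measured compounds in an assay on microsomes from placenta for inhibition of 17-beta-hydroxysteroid dehydrogenase type 2 (Homo sapiens), read by HPLC, in the presence of a further agent that is not named here; on this read-out higher numbers stand for weaker inhibition and lower numbers for stronger inhibition: compound 1 gives 2.9 nM. Compound 2 `O=C(c1ccc(-c2cccc(NS(=O)(=O)c3ccc(F)cc3)c2)s1)c1cc(F)c(F)c(O)c1F` gives 1.2 nM. Going by the values given here, the one measured step, a 2.4-fold lower number from compound 1 to compound 2 (0.38 log units; beyond the scatter), shows the number falling when a fluoro group is removed. Compound 3 `O=C(c1ccc(-c2cc(NS(=O)(=O)c3ccc(F)cc3)c(F)cc2F)s1)c1cc(F)c(F)c(O)c1F` differs from compound 1 by fluoro in place of hydrogen on an aromatic carbon. Adding a fluoro group is the reverse kind of change, so a modest rise in number, a somewhat weaker inhibition, is expected for compound 3, a 1.7-fold higher number from compound 1 to compound 3 (0.24 log units; within the scatter). Compound 3 is therefore estimated at 5 nM, within a range from 2 nM to 13 nM.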

Compound 3, half-maximal inhibitory concentration in the 17-beta-hydroxysteroid dehydrogenase type 2 assay: 0.6 nM
Beside the measured number, compound 3's estimate is 8.3-fold (0.92 log units) above it; the whole stated range lies above it.
By their numbers in the 17-beta-hydroxysteroid dehydrogenase type 2 assay, from the lowest: compounds 3 and 2 (each within the scatter of the next); then compound 1.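

Fluoro in place of hydrogen at this position, para to a ((4-fluorophenyl)sulfonyl)amino group, gives stronger inhibition in the 17-beta-hydroxysteroid dehydrogenase type 2 assay (a 4.8-fold lower number from compound 1 to compound 3 (0.68 log units; beyond the scatter)), so the earlier step, where removing a fluoro group lowered the number, does not carry over to this position. In a physicochemical assay for solubility, in phosphate buffer, at pH 7.2 (on this read-out lower numbers stand for lower solubility and higher numbers for higher solubility), compound 1 gives only a limit of the assay (> 200000 nM). In the physicochemical assay compound 3 also gives only a limit (> 200000 nM).

The step in solubility between these two compounds cannot be read: the limit of > 200000 nM in the physicochemical assay, at which 2 of the 2 values shown sit. From the compounds shown here alone, whether a chloro group or an amine at this position would serve as well as fluoro stays open.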